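The source may report more compounds than this note shows. Statements on the series, on what has been measured and on what is new or still open speak of the compounds shown alone.

In an ADME assay on THP-1 cells (Homo sapiens) for cytotoxicity, read by flow cytometry and propidium iodide staining, with a stated time of 72 h (a lower number here means a stronger inhibitor, a higher number a weaker inhibitor), two compounds have been measured so far:
compound 1 `CC(=O)Nc1ccc2oc(-c3ccccc3)c(O)c(=O)c2c1` gives 36000 nM
compound 2 `Nc1ccc2oc(-c3ccccc3)c(O)c(=O)c2c1` gives 27000 nM

These two values lie within the scatter of each other, so compound 2 cannot be ranked apart from compound 1. Among the measured compounds shown here, the one measured step, a 1.3-fold lower number from compound 1 to compound 2 (0.12 log units; within the scatter), involves hydrogen in place of acetyl on a nitrogen on an aromatic ring.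

The next compound is compound 3 `Nc1ccc2oc(-c3cccc(F)c3)c(O)c(=O)c2c1`, which differs from compound 2 by a single change (fluoro in place of hydrogen on an aromatic carbon). This is fluoro in place of hydrogen on an aromatic carbon of a six-membered aromatic ring of carbon only, meta to a large group.

For the measured compounds named here, no measured step touches that ring, so the data hold no direct precedent for this change. Going by the values given here, the step at the nitrogen is the only guide, and it stayed within the scatter. Starting from compound 2 at 27000 nM, no shift beyond the scatter is therefore expected in this assay. The estimated step is small (a 1.1-fold lower number from compound 2 to compound 3 (0.03 log units; within the scatter)). Compound 3 is expected to read about 25000 nM (estimated range 12000 nM to 50000 nM).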

Compound 3, half-maximal inhibitory concentration: 30000 nM
Estimate against measurement, compound 3: 1.2-fold (0.08 log units) below; low and high end bracket the measured number.
By their numbers in this assay, from the lowest: compounds 2, 3 and 1 (each within the scatter of the next).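

In this assay, fluoro in place of hydrogen on an aromatic carbon of the six-membered aromatic ring of carbon only, meta to a large group, gives a 1.1-fold higher number from compound 2 to compound 3 (0.05 log units; within the scatter). Among the compounds shown here, this is the first reading at this ring, since the only earlier step, a 1.3-fold lower number from compound 1 to compound 2 (0.12 log units; within the scatter), concerned the nitrogen, so compound 2 and compound 3 cannot be told apart and a single fluoro at this place has no effect that this assay can resolve. Nothing measured here offers an explanation for this result.

The compounds shown leave open whether trifluoromethyl, methoxy or a carboxylic acid at the same place would also stay within the scatter, and whether fluoro would do so elsewhere on this ring. They also leave open whether a longer chain on the nitrogen, in place of the acetyl of compound 1, would move the number beyond the scatter.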